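This account rests on a few compounds, and the source may have more. Where it says the series, first, only, none or still open, it means among the compounds named here.

The measured compounds: compound 1 `O=C(Nc1nccs1)c1cc(=O)c2ccccc2o1`, compound 2 `Cc1ccc2oc(C(=O)Nc3nnn[nH]3)cc(=O)c2c1`, compound 3 `CC(=O)Oc1ccc2c(=O)cc(C(N)=O)oc2c1`.

In a functional assay on cells (Mast cell, Rattus norvegicus) for inhibition, with a stated time of 15 min (on this read-out lower numbers stand for an effect already at smaller amounts and higher numbers for an effect only at larger amounts of compound), compound 1 gives only a limit, > 18 ug/mL, and so stands at the limit of > 18 ug/mL in this assay, at which 1 of the 3 values shown sits. Compound 2 gives 0.075 ug/mL in this assay. For compound 3 the entry in this assay reads "nd(insoluble)" (no result reported), so no number stands for it. The unmeasured compound 4 `O=C(O)CCCNC(=O)c1cc(=O)c2ccccc2o1` differs from compound 1 in one place: 3-carboxypropyl in place of 1,3-thiazol-2-yl on an amide-type nitrogen. Among the compounds with values here, no step between two measured compounds is available, so the size of this change in this assay is judged from compound 1 alone. The step is expected to go beyond the scatter toward smaller amounts: an at least 3.6-fold lower number from compound 1 to compound 4 (0.55 log units; beyond the scatter). Compound 4 is estimated at 5 ug/mL in this assay, with a range from 0.5 ug/mL to 50 ug/mL.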

Compound 4, concentration for half-maximal effect: > 18 ug/mL
Compound 4: only a limit was reported; the forecaster's own chance of this, stated with the estimate: 35%; middle value at least 3.6-fold (0.55 log units) away from the limit.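

Within the data shown here, compound 1 and compound 4 both give only a limit in this assay, so no step between them can be read: the limit of > 18 ug/mL in this assay, at which 2 of the 4 values shown sit.

The compounds shown leave open whether 3-carboxypropyl in place of 1,3-thiazol-2-yl on the amide-type nitrogen changes this read-out at all.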